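This account rests on a few compounds, and the source may have more. Where it says the series, first, only, none or still open, it means among the compounds named here.

The measured compounds come first. Compound 1 `CC(C)N(Cc1cccc(OCCCCCC(=O)O)c1)C(=O)c1ccc(-c2cccc3ccccc23)cc1` is the parent. In an ADME assay on HepG2 cells (Homo sapiens) for cytotoxicity, read by CellTiter-Glo and resazurin assay, with a stated time of 72 h (on this read-out higher numbers stand for an effect only at larger amounts of compound and lower numbers for an effect already at smaller amounts), compound 1 gives > 26000 nM, which is a limit of the assay and not a number. Compound 2 `CC(=O)c1cccc(-c2ccc(C(=O)N(Cc3cccc(OCCCCCC(=O)O)c3)C(C)C)cc2)c1` carries a 3-acetylphenyl group. In this assay compound 2 gives > 26000 nM, again a limit. Compound 3 `CCOC(=O)CCCCCOc1cccc(CN(C(=O)c2ccc(-c3cccc4ccccc34)cc2)C(C)C)c1` is the ethyl ester. In this assay compound 3 gives > 26000 nM, also a limit.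

Compound 3 therefore stands where every value in this set stands: at the limit of > 26000 nM in this assay, at which 3 of the 3 values shown sit, with no number to place it above or below its companions. Compound 4 `CCOC(=O)CCCCCOc1cccc(CN(C(=O)c2ccc(-c3cccc(-c4nnc(C)o4)c3)cc2)C(C)C)c1` is not yet measured and differs from compound 3 by 3-(5-methyl-1,3,4-oxadiazol-2-yl)phenyl in place of naphthalen-1-yl on an aromatic carbon.

Among the measured compounds shown here, two measured steps bear on this change. The exchange of the naphthalen-1-yl for 3-acetylphenyl, a step that the two limits leave unreadable from compound 1 to compound 2, is the closest analogy, and the ester step that the two limits leave unreadable from compound 1 to compound 3 shows that the ester end of the chain did not move the read-out either. Both steps are unreadable because the limit of > 26000 nM in this assay, at which 3 of the 3 values shown sit, holds every value. He therefore expects no step beyond the scatter, a step that the limit leaves unreadable from compound 3 to compound 4, for compound 4. His estimate for compound 4 in this assay is 30000 nM, with a range from 15000 nM to 80000 nM, most likely reported again as a limit.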

Compound 4, half-maximal effective concentration: > 26000 nM
Compound 4 was reported as a limit; the forecaster's own chance of this, stated with the estimate: 85%; the middle value is on the limit's open side.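

No step can be read from compound 3 to compound 4, since the values of both are limits of the assay and not numbers: the limit of > 26000 nM in this assay, at which 4 of the 4 values shown sit.

The compounds shown leave open at what concentration, if any, this assay would give a number for any of them, and so how naphthalen-1-yl, 3-acetylphenyl and 3-(5-methyl-1,3,4-oxadiazol-2-yl)phenyl compare.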